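The compounds below may be only part of what the source reports. "The series", "measured", "known", "first", "only" and "open" are said of these compounds alone.

Compound 1 `COc1ncnc2c1c(-c1ccsc1)cn2[C@@H]1O[C@H](CO)[C@@H](O)[C@H]1O` and compound 2 `Cc1ncnc2c1c(-c1ccsc1)cn2[C@@H]1O[C@H](CO)[C@@H](O)[C@H]1O` share one core and differ by a methyl in place of a methoxy on an aromatic carbon. In an ADME assay on MRC5 cells (Homo sapiens), read by MTT assay, with a stated time of 72 h (on this read-out lower numbers stand for stronger inhibition and higher numbers for weaker inhibition), compound 1 gives 75300 nM. Going by these compounds, for compound 2 this assay reports only a limit, > 100000 nM, so its true number is unknown (the limit of > 100000 nM in this assay, at which 1 of the 2 values shown sits). The step of an at least 1.3-fold higher number from compound 1 to compound 2 (0.12 log units; that floor lies within the scatter) is therefore small. Compound 3 `CSc1ncnc2c1c(-c1ccsc1)cn2[C@@H]1O[C@H](CO)[C@@H](O)[C@H]1O` carries methylsulfanyl in place of methyl on an aromatic carbon. For the measured compounds named here, only that single step bears on this change, and it sits within the scatter, so no shift beyond the scatter is expected. Compound 3 is estimated at 100000 nM, between 40000 nM and 300000 nM, an expected step of a number no higher from compound 2 to compound 3 (the limit leaves the size open).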

Compound 3, half-maximal inhibitory concentration: > 100000 nM
Compound 3: only a limit was reported; the forecaster's own chance of this, stated with the estimate: 55%; the middle value lies on the limit itself.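

Compound 3, with methylsulfanyl at this position, also gives only a limit in this assay, so compound 1 with its methoxy remains the only one of the three with an actual number. Set against compound 1, the change gives an at least 1.3-fold higher number from compound 1 to compound 3 (0.12 log units; that floor lies within the scatter), so no shift beyond the scatter can be claimed. The step between compound 2 and compound 3 cannot be read because both values are limits: the limit of > 100000 nM in this assay, at which 2 of the 3 values shown sit.

Going by these compounds, the true values of compound 2 and compound 3 stay unknown. Also open, on these data alone, is whether an amine or a longer chain at this position would give a number clearly different from that of compound 1.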